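Indolyl in place of methoxyphenyl on a shared pyrazolopyrimidine-type core

A few compounds are considered here, and "the series" means these few. Any claim that something is new, unique, unknown or untested is made for them only; others in the source may bear on it.

Measured compounds:
- compound 1, `COc1ccc(-c2cc3nccc(-c4cc(OC)c(OC)c(OC)c4)n3n2)cc1F`, 2840 nM
- compound 2, `COc1cc(-c2ccnc3cc(-c4ccccc4)nn23)cc(OC)c1OC`, 3880 nM
- compound 3, `COc1ccc(-c2cc3nccc(-c4cc(OC)c(OC)c(OC)c4)n3n2)cc1`, 404 nM

Of the compounds shown here, three sharing one core have been tested in a functional assay on HCT-116 cells (Homo sapiens) for inhibition, read by CCK-8 assay, with a stated time of 48 h; on this read-out lower numbers stand for stronger inhibition and higher numbers for weaker inhibition. Compound 3 stands lowest of the three: compound 1 is nearest to it, with a 7.0-fold lower number from compound 1 to compound 3 (0.85 log units; beyond the scatter) describing the gap on removal of the fluoro, and compound 2 is furthest, with a 9.6-fold lower number from compound 2 to compound 3 (0.98 log units; beyond the scatter) describing the gain on adding the methoxy. Compound 1 and compound 2 differ from each other only by a 1.4-fold higher number from compound 1 to compound 2 (0.14 log units; within the scatter).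

Compound 4, `COc1cc(-c2ccnc3cc(-c4ccc5c(ccn5C)c4)nn23)cc(OC)c1OC`, has not yet been measured in this assay. It differs from compound 3 in one place: 1-methyl-1H-indol-5-yl in place of 4-methoxyphenyl on an aromatic carbon.

Going by the values given here, no measured step exchanges the whole aryl group at this position; the steps seen so far concern only substituents on that ring. The step from compound 2 to compound 3 shows that a group at this position can shift the number by a modest amount, so a change of similar size in either direction seems possible for compound 4. On balance compound 4 is expected to give a somewhat higher number, a 2.2-fold higher number from compound 3 to compound 4 (0.35 log units; beyond the scatter), with an estimate of 900 nM and a range from 200 nM to 4000 nM.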

Compound 4, half-maximal inhibitory concentration: 39 nM
For compound 4 the middle estimate is 23-fold (1.36 log units) above the measured one; the measured number lies below the stated range.
By their numbers in this assay, from the lowest: compound 4; then compound 3; then compounds 1 and 2 (each within the scatter of the next).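

In this assay, the exchange of the whole aryl group on this aromatic carbon gives a 10-fold lower number from compound 3 to compound 4 (1.02 log units; beyond the scatter), which shows that the position accepts 1-methyl-1H-indol-5-yl in place of 4-methoxyphenyl and that the earlier changes on the phenyl ring did not mark the lowest number reachable here. Going by these compounds alone, the gaps to the other two compounds are wider than any step among the earlier compounds, with a 99-fold lower number from compound 2 to compound 4 (2.00 log units; beyond the scatter) and a 73-fold lower number from compound 1 to compound 4 (1.86 log units; beyond the scatter), so compound 4 now stands clearly lowest of the four, and the choice of aryl group at this position spans a much wider range of numbers than the earlier compounds showed. Nothing available on these compounds accounts for the gain, so it stands here as an observation only.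

The compounds shown leave open whether the gain belongs to the indole ring itself or to its 1-methyl group, as no 1H-indol-5-yl with hydrogen on the ring nitrogen appears among them. They also leave open how a 1-methyl-1H-indol-5-yl ring carrying an amine or a carboxylic acid would read out in this assay.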